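This account rests on a few compounds, and the source may have more. Where it says the series, first, only, none or still open, it means among the compounds named here.

Compound 1, `CC(C)(N)C(=O)N[C@H](COCc1ccccc1)c1nnnn1CCCc1ccccc1`, anchors the series: in an assay on isolated protein for displacement of a labelled ligand from growth hormone secretagogue receptor type 1 (Homo sapiens), with a stated time of 1 h (a higher number here means a weaker inhibitor, a lower number a stronger inhibitor), compound 1 gives 200 nM. Compound 2, `CC(C)(N)C(=O)N[C@H](COCc1ccccc1)c1nnn(Cc2ccc(NS(C)(=O)=O)cc2)n1`, carries a 4-(methanesulfonamido)phenyl group on the saturated chain carbon bound to an aromatic nitrogen of the shared core. In this assay compound 2 reaches only a limit, > 5000 nM, so no number is known for it. This is the situation described by the limit of > 5000 nM in this assay, at which 1 of the 2 values shown sits: one of the two values shown sits at the limit rather than at a measured point, and compound 2 is that one.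

Compound 3, `CC(C)(N)C(=O)N[C@H](COCc1ccccc1)c1nnn(CCCCC#N)n1`, is not yet measured. The change from compound 2 to compound 3 is 3-cyanopropyl in place of 4-(methanesulfonamido)phenyl on a saturated chain carbon bound to an aromatic nitrogen. For the measured compounds named here, no measured step between any two compounds is available to calibrate this change, and compound 2 itself offers only a limit, so the direction of the step cannot be read from the data. Compound 3 is expected to show 2500 nM, within a range of 500 nM to 12000 nM, and the step from compound 2 to compound 3 that this estimate implies is an at least 2.0-fold lower number from compound 2 to compound 3 (0.30 log units; that floor lies within the scatter), with a real chance that compound 3 also returns only a limit.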

Compound 3, inhibition constant: > 5000 nM
Compound 3: a limit, no number; the forecaster's own chance of this, stated with the estimate: 40%; middle value at least 2.0-fold (0.30 log units) from the limit.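

In this assay compound 3 returns only a limit, > 5000 nM, and no number. No step from compound 2 to compound 3 can be read, since the two compounds stop at the same point: the limit of > 5000 nM in this assay, at which 2 of the 3 values shown sit.

The compounds shown leave open how far compound 2 and compound 3 lie beyond that limit, and which of them is the stronger inhibitor.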